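Swapping an Allyloxy for a Cyclopentylsulfanyl on Compound 1

The compounds below may be only part of what the source reports. "The series", "measured", "known", "first", "only" and "open" are said of these compounds alone.

The three measured compounds share one core, seen in compound 1 `C=CCOc1nc(N)nc2c1ncn2/C=C1/CC1(CO)CO`, and differ only in the group carried on one aromatic carbon. All were tested in an ADME assay on CCRF-HSB-2 cells (Homo sapiens) for cytotoxicity, with a stated time of 7 days; a higher number here means that more compound is tolerated, a lower number that less compound is tolerated. In this assay compound 1 gives > 20000 nM, which is a limit of the assay and not a number. Compound 2 `CCOc1nc(N)nc2c1ncn2/C=C1/CC1(CO)CO` gives > 20000 nM, again a limit. Compound 3 `CCCCCCCCSc1nc(N)nc2c1ncn2/C=C1/CC1(CO)CO` gives a real number, 60000 nM. Because of the limit of > 20000 nM in this assay, at which 2 of the 3 values shown sit, the step that the two limits leave unreadable from compound 1 to compound 2 cannot be sized, and the same is true of a step that the limit leaves unreadable from compound 1 to compound 3 and a step that the limit leaves unreadable from compound 2 to compound 3. What the numbers do show is that none of the three compounds is toxic to these cells at the concentrations tested.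

Compound 4 `Nc1nc(SC2CCCC2)c2ncn(/C=C3/CC3(CO)CO)c2n1` has not yet been measured. It differs from compound 1 by cyclopentylsulfanyl in place of allyloxy on an aromatic carbon. The steps that come closest to this change are those that also bring in a sulfanyl group, from compound 1 and from compound 2 to compound 3, and both are unreadable in size. With compound 3 still tolerated at 60000 nM, compound 4 is expected to be tolerated in a similar way, estimated at 40000 nM with a range from 15000 nM to 100000 nM. The expected step is a step that the limit leaves unreadable from compound 1 to compound 4, and a further limit rather than a number is quite possible.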

Compound 4, half-maximal cytotoxic concentration: 91000 nM
Compound 4: middle estimate off by 2.3-fold (0.36 log units), on the low side; the measured number falls inside the stated range.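

In this assay, going by these compounds alone, replacing the octyl on the sulfur with a cyclopentyl gives a 1.5-fold higher number from compound 3 to compound 4 (0.18 log units; within the scatter), the first step in this set whose size can be read. At this aromatic carbon, a sulfanyl group carrying a straight octyl chain and one carrying a five-membered carbon ring therefore cannot be told apart in how much compound the cells tolerate, although this rests on just these two compounds. The allyloxy compound 1 and the ethoxy compound 2 each carry only a limit of the assay, so the new result cannot show whether the sulfanyl compounds differ from them, and their steps to compound 4 cannot be read because of it: the limit of > 20000 nM in this assay, at which 2 of the 4 values shown sit.

Whether the sulfur itself matters stays open, as each pair shown that swaps oxygen for sulfur also changes the group attached to it, and a cyclopentyloxy group would be the direct partner to compound 4. Also open, going by these compounds, is how an amine such as cyclopentylamino, or a short methylsulfanyl group, at this same carbon would behave in this assay.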